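This account rests on a few compounds, and the source may have more. Where it says the series, first, only, none or still open, it means among the compounds named here.

Of the compounds shown here, three have been read in a functional assay on U-251 cells (Homo sapiens) for inhibition, read by sulforhodamine B assay, with a stated time of 48 h; a higher number here means a weaker inhibitor of growth, a lower number a stronger inhibitor of growth. Compound 1 `CC1(/C=C/c2ccc(C(F)(F)F)cc2)C=CC(=O)O1` gives 15700 nM in this test, compound 2 `COc1ccc(/C=C/C2(C)C=CC(=O)O2)c(OC)c1` gives 62800 nM and compound 3 `COc1ccc(/C=C/C2(C)C=CC(=O)O2)cc1OC` gives 193000 nM as the highest number of the three. Compound 3 is therefore the weakest growth inhibitor so far, and its gaps to both others lie beyond the scatter.

The next compound, compound 4 `COc1ccc(/C=C/C2(C)C=CC(=O)O2)c(OC)c1OC`, keeps the core and both methoxy groups of compound 3 and changes one place (methoxy in place of hydrogen on an aromatic carbon). Going by the values given here, no measured pair isolates such a change, so the expectation is loose. Among the compounds with values here, the only guide is that two methoxy groups arranged differently give different values: compound 2 reads 62800 nM and compound 3 reads 193000 nM in the same test. A modest fall in the number is expected, although a result within the scatter would not surprise. a 1.9-fold lower number from compound 3 to compound 4 (0.29 log units; within the scatter) is the estimated move. The estimated value for compound 4 is 100000 nM with an expected range from 35000 nM to 250000 nM in this test.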

Compound 4, concentration for total growth inhibition: 87200 nM
Compound 4: middle estimate off by 1.1-fold (0.06 log units), on the high side, and the stated range covers the measured number.
By their numbers in this assay, from the lowest: compound 1; then compounds 2 and 4 (each within the scatter of the next); then compound 3.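

In this assay methoxy in place of hydrogen, on the aromatic carbon ortho to a group of 9 heavy atoms and ortho to a methoxy group, gives a 2.2-fold lower number from compound 3 to compound 4 (0.35 log units; beyond the scatter) as a modest step. Read from compound 2, the other one-place change gives a 1.4-fold higher number from compound 2 to compound 4 (0.14 log units; within the scatter) and so leaves compound 2 and compound 4 level within the scatter: a methoxy group entering the ring counts clearly on compound 3 only, and two steps cannot carry a wider rule. No evidence at hand bears on what lies behind either step.

As far as these compounds go, whether this aromatic carbon tolerates anything other than methoxy remains open, for instance a hydroxyl group, a fluorine atom or a longer ethoxy chain. Also open, from the compounds shown here alone, is whether a methoxy group added to compound 1 would move its number at all.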